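Pyrazinyl in place of N-methyl on a thienylmethyl amide

The compounds below may be only part of what the source reports. "The series", "measured", "known", "first", "only" and "open" are said of these compounds alone.

Measured compounds:
compound 1, `Cc1ccc(OCC(=O)N(C)Cc2cccs2)cc1`, 400 nM
compound 2, `CCN(Cc1cccs1)C(=O)COc1ccc2c(c1)CCC2`, 0.8 nM

Of the compounds shown here, two have been measured in an assay on HEK293 cells for agonist activity at transient receptor potential cation channel subfamily M member 8 (Homo sapiens), read by fluorescence and calcium flux, with a stated time of 15 min; a higher number here means that more compound is needed for the effect, a lower number that less compound is needed. Compound 1 gives 400 nM, the higher of the two numbers. Among the compounds with values here, compound 2, the only other compound with a value, gives 0.8 nM, a number far lower than that of compound 1 and well beyond the usual scatter of the measurement. Compound 2 differs from compound 1 in several places at once, so its value cannot be tied to any single change.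

Compound 3, `Cc1ccc(OCC(=O)N(Cc2cccs2)c2cnccn2)cc1`, is the compound still to be measured. It is derived from compound 1 by one alteration: pyrazin-2-yl in place of methyl on an amide-type nitrogen. Within the data shown here, nothing among the measured compounds isolates this change, so no step of known size can be carried over. In the absence of a comparable pair, the step from compound 1 to compound 3 is expected to be small, a modest move toward a lower number at most, and not clearly beyond the scatter: a 1.3-fold lower number from compound 1 to compound 3 (0.12 log units; within the scatter). Compound 3 is therefore estimated at 300 nM, with a range from 60 nM to 1500 nM.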

Compound 3, half-maximal effective concentration: 1240 nM
For compound 3 the middle estimate is 4.1-fold (0.62 log units) below the measured one, within the range that was stated.
By their numbers in this assay, from the lowest: compound 2; then compound 1; then compound 3.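

Pyrazin-2-yl in place of methyl on the amide-type nitrogen, whose other neighbours are the carbonyl carbon and a saturated chain carbon, is the first single change that can be read in this assay, and it gives a 3.1-fold higher number from compound 1 to compound 3 (0.49 log units; beyond the scatter). The earlier compounds shown here could not show this, as compound 2 differs from compound 1 in several places at once. The step shows that this position can carry a six-membered aromatic ring with 2 hetero atoms, bringing 6 heavy atoms and 2 hydrogen-bond acceptors in place of 1 heavy atom, at a modest rise in the number; nothing shown here bears on the reason for that rise.

Still open, as far as these compounds go, is whether the step belongs to the aromatic ring as such or to its nitrogen atoms, a question that phenyl or pyridin-2-yl on the same amide-type nitrogen would address. Also open, from the compounds shown here alone, is whether a longer chain, such as n-butyl, on this nitrogen would move the number up or down, and whether pyrazin-2-yl would give a step of similar size on the core of compound 2.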